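The compounds below may be only part of what the source reports. "The series", "measured", "known", "first", "only" and "open" are said of these compounds alone.

In a functional assay on Caco-2 cells (Homo sapiens) for antiproliferative activity, read by MTT assay, with a stated time of 48 h (a lower number here means a stronger inhibitor, a higher number a weaker inhibitor), the measured compounds read:

- compound 1 `CCN(CC)CCNC(=O)c1ccc(C(CC)(CC)c2ccc(OCCC(O)(CC)CC)c(C)c2)n1CC`: 1630 nM
- compound 2 `CCn1c(C(=O)NCCN)ccc1C(CC)(CC)c1ccc(OCCC(O)(CC)CC)c(C)c1`: 1740 nM
- compound 3 `C#CC(C)OC(=O)c1ccc(C(CC)(CC)c2ccc(OCCC(O)(CC)CC)c(C)c2)n1CC`: > 50000 nM

Compound 3 stands at > 50000 nM, which is a limit of the assay and not a number.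

Compound 4 `C#CCCOC(=O)c1ccc(C(CC)(CC)c2ccc(OCCC(O)(CC)CC)c(C)c2)n1CC` has the same atoms as compound 3, joined differently: but-3-yn-1-yl in place of 1-methylprop-2-yn-1-yl on an oxygen next to a carbonyl group. In words, but-3-yn-1-yl stands in place of 1-methylprop-2-yn-1-yl on an oxygen next to a carbonyl group.

For the measured compounds named here, no measured step compares these two groups directly. The nearest are an at least 30-fold higher number from compound 1 to compound 3 (1.48 log units; beyond the scatter) and an at least 28-fold higher number from compound 2 to compound 3 (1.45 log units; beyond the scatter), both large, and each replaces an amino-bearing chain with (1-methylprop-2-yn-1-yl)oxy on the carbonyl carbon. By contrast, a 1.1-fold higher number from compound 1 to compound 2 (0.03 log units; within the scatter) stays within the scatter. Compound 4 keeps the carbonyl-oxygen link of compound 3 and has no amino-bearing chain, so it is expected to remain on the weak side of this assay.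

The expected change is an at least 1.1-fold lower number from compound 3 to compound 4 (0.04 log units; that floor lies within the scatter), with no step beyond the scatter anticipated. The estimate for compound 4 is 45000 nM, with an expected range from 12000 nM to 90000 nM.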

Compound 4, half-maximal inhibitory concentration: > 50000 nM
Compound 4: a limit, no number (the forecaster's own chance of this, stated with the estimate: 70%); middle value at least 1.1-fold (0.04 log units) away from the limit.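

In this assay compound 4 gives > 50000 nM, which is a limit of the assay and not a number. The step between compound 3 and compound 4 cannot be read, because both stand at the same limit: the limit of > 50000 nM in this assay, at which 2 of the 4 values shown sit. The large steps seen for compound 3 recur with the other chain, an at least 28-fold higher number from compound 2 to compound 4 (1.45 log units; beyond the scatter) and an at least 30-fold higher number from compound 1 to compound 4 (1.48 log units; beyond the scatter), so the loss relative to the amino-bearing chains on the carbonyl carbon does not depend on which of these two groups, but-3-yn-1-yl or 1-methylprop-2-yn-1-yl, sits on the oxygen.

The compounds shown leave open whether this loss follows the oxygen link or the triple bond, a question that a saturated butyl group on the same oxygen would address. On these data alone, how a carboxylic acid at that carbonyl carbon would read also remains open.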